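The source may hold more compounds than are shown below. What is called first, only, known or untested is meant among the compounds shown, and "the series" means these compounds.

Compound 1 `C=Cc1csc(Br)n1` and compound 2 `C=Cc1nc(C(=O)OCC)cs1` have different cores, and that difference is not broken down here. In a functional assay on HCT-116 cells (Homo sapiens) for cytotoxicity, with a stated time of 3 days (a higher number here means a weaker inhibitor, a lower number a stronger inhibitor), compound 1 gives only a limit of the assay, > 40000 nM. In this assay compound 2 also gives a limit, > 40000 nM. Compound 3 `C#Cc1nc(C(=O)OCC)cs1` differs from compound 2 by ethynyl in place of vinyl on an aromatic carbon. In this assay compound 3 again gives a limit, > 40000 nM. The step that the two limits leave unreadable from compound 2 to compound 3 is unreadable because of the limit of > 40000 nM in this assay, at which 3 of the 3 values shown sit. Compound 4 `C#Cc1csc(Br)n1` carries the same kind of change on the core of compound 1, (ethynyl in place of vinyl on an aromatic carbon); its place is two ring bonds from the ring sulfur and two ring bonds from the ring atom that bears a bromo group, whereas in compound 3 the place is next to the ring sulfur and two ring bonds from the ring atom that bears a group of 5 heavy atoms. Compound 4 is expected to remain at the limit, with an estimated 60000 nM. This expectation rests on compound 1, which gives > 40000 nM, and on (the limit of > 40000 nM in this assay, at which 3 of the 3 values shown sit). The expected step that the limit leaves unreadable from compound 1 to compound 4 is therefore small.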

Compound 4, half-maximal inhibitory concentration: > 40000 nM
Compound 4: only a limit was reported; the forecaster's own chance of this, stated with the estimate: 90%; the middle value lies beyond the limit too.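

Compound 1 and compound 4 both give only a limit in this assay, so no step can be read between them: the limit of > 40000 nM in this assay, at which 4 of the 4 values shown sit.

The compounds shown leave open whether ethynyl in place of vinyl has any effect on cytotoxicity on either core.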